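Double-bond geometry in a carboxylic acid chain

The source may hold more compounds than are shown below. What is called first, only, known or untested is meant among the compounds shown, and "the series" means these compounds.

- Compound 1 `Cc1c(Cc2cccnc2)cc2c(c1CCC(=O)O)CCC(NS(=O)(=O)c1ccc(Cl)cc1)C2`: 610 nM
- Compound 2 `O=C(O)CCC/C=C\c1cc(Cc2cccnc2)cc2c1CCC(NS(=O)(=O)c1ccc(Cl)cc1)C2`: 90 nM
- Compound 3 `Cc1c(Cc2cccnc2)cc2c(c1/C=C/CCCC(=O)O)CCC(NS(=O)(=O)c1ccc(Cl)cc1)C2`: 460 nM

These numbers come from a functional assay for inhibition, with Homo sapiens as the target; a higher number here means a weaker inhibitor, a lower number a stronger inhibitor. Compound 3 gives 460 nM, level with compound 1 within the scatter. Compound 2 gives 90 nM, a clearly lower number than that of compound 3.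

Compound 4 `Cc1c(Cc2cccnc2)cc2c(c1/C=C\CCCC(=O)O)CCC(NS(=O)(=O)c1ccc(Cl)cc1)C2` is the next to consider. Compared with compound 3, (the two compounds have the same atoms and bonds; at least one stereo element is drawn with a configuration in one of them and without one in the other: 1 of 2 stereo elements differ; a double bond is drawn E in compound 3 and Z in compound 4).

Going by the values given here, no measured step isolates this change. The nearest one, a 1.3-fold lower number from compound 1 to compound 3 (0.12 log units; within the scatter), replaces 2-carboxyethyl with 5-carboxypent-1-en-1-yl and does not test double-bond geometry. Among the compounds with values here, the only hint is indirect: compound 2, the one measured compound with a double bond drawn Z, gives 90 nM. A modest move toward lower numbers therefore seems likely, though this rests on a single compound and is uncertain. The expected change is a 2.3-fold lower number from compound 3 to compound 4 (0.36 log units; beyond the scatter).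

For compound 4 the estimated value is 200 nM, with an expected range from 70 nM to 550 nM.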

Compound 4, half-maximal inhibitory concentration: 1000 nM
The estimate for compound 4 lay 5.0-fold (0.70 log units) below the measured number; the measured number lies above the stated range.
By their numbers in this assay, from the lowest: compound 2; then compounds 3, 1 and 4 (each within the scatter of the next, the first and the last beyond it).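

In this assay, the geometry of the double bond in the 5-carboxypent-1-en-1-yl chain does matter, and the Z form gives the higher number: a 2.2-fold higher number from compound 3 to compound 4 (0.34 log units; beyond the scatter). Methyl in place of hydrogen on an aromatic carbon, with the Z bond kept, is a far larger step, an 11-fold higher number from compound 2 to compound 4 (1.05 log units; beyond the scatter), so the low number seen earlier goes with the missing methyl and not with the Z bond by itself. The longer Z chain also offers no clear change from the shorter 2-carboxyethyl chain: a 1.6-fold higher number from compound 1 to compound 4 (0.21 log units; within the scatter).

One caution applies to reading the geometry step: the fact that one of compounds 3 and 4 is drawn with a defined configuration and the other without, at the place where they differ. Still open, as far as these compounds go, is whether the E chain without the methyl would also give a low number, and whether an ethyl group or a fluorine in place of the methyl would act as the methyl does.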